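Piperidine methylation on the trifluoromethoxyphenyl pyridazinone series

A few compounds are considered here, and "the series" means these few. Any claim that something is new, unique, unknown or untested is made for them only; others in the source may bear on it.

Compound 3 `COc1cc2c(Oc3ccc(NC(=O)c4nn(-c5ccccc5OC(F)(F)F)c(=O)cc4C)cc3F)ccnc2cc1OCCCN1CCCCC1` sits at 190 nM in a functional assay on HT-29 cells (Homo sapiens) for inhibition, read by MTT assay, with a stated time of 72 h (on this read-out lower numbers stand for stronger inhibition and higher numbers for weaker inhibition), the second highest of the three numbers recorded. Compound 2 `COc1cc2c(Oc3ccc(NC(=O)c4nn(-c5ccccc5OC(F)(F)F)c(=O)cc4C)cc3F)ccnc2cc1OCCCN1CCCC1` gives 180 nM in this assay, and compound 1 `COc1cc2c(Oc3ccc(NC(=O)c4nn(-c5ccccc5C)c(=O)cc4C)cc3F)ccnc2cc1OCCCN1CCC(C)CC1` gives 2810 nM; compound 1 differs from compound 3 in two places, so its number cannot be assigned to either change alone.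

Compound 4 `COc1cc2c(Oc3ccc(NC(=O)c4nn(-c5ccccc5OC(F)(F)F)c(=O)cc4C)cc3F)ccnc2cc1OCCCN1CCC(C)CC1` is compound 3 with methyl in place of hydrogen on a saturated ring carbon. Within the data shown here, the one single-point step measured on this chain end, a 1.1-fold higher number from compound 2 to compound 3 (0.02 log units; within the scatter), shows that exchanging the whole saturated ring left the number essentially unchanged in this assay. Among the measured compounds shown here, no step measuring a methyl added to the piperidine ring alone exists in the set, and compound 1 carries a different aryl group, so its value gives no clean reading on the methyl.

The step from compound 3 to compound 4 is therefore expected to be a 1.3-fold higher number from compound 3 to compound 4 (0.12 log units; within the scatter), with no direction beyond the scatter favoured. Compound 4 is estimated at 250 nM in this assay, within a range from 90 nM to 700 nM.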

Compound 4, half-maximal inhibitory concentration: 250 nM
Beside the measured number, compound 4's estimate shows no gap at the digits printed, and the stated range covers the measured number.
By their numbers in this assay, from the lowest: compounds 2, 3 and 4 (each within the scatter of the next); then compound 1.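

In this assay the methyl on the piperidine ring, three ring bonds from the ring nitrogen, can now be read alone as a 1.3-fold higher number from compound 3 to compound 4 (0.12 log units; within the scatter) and the full exchange of the chain end as a 1.4-fold higher number from compound 2 to compound 4 (0.14 log units; within the scatter) so the pyrrolidin-1-yl, piperidin-1-yl and 4-methylpiperidin-1-yl ends all lie within the scatter of one another. With the 4-methylpiperidin-1-yl end held fixed, the aryl change can also be read cleanly as an 11-fold lower number from compound 1 to compound 4 (1.05 log units; beyond the scatter) and this trifluoromethoxy for methyl exchange, unlike the changes at the chain end, lies beyond the scatter. Nothing available bears on the cause of either result.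

Open is whether a morpholin-4-yl or dimethylamino end on the same chain would stay within the scatter of these compounds. Also open, on these data alone, is whether the aryl step carries over to the pyrrolidin-1-yl and piperidin-1-yl ends.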